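Hydroxy for 2-aminophenyl on the amide of compound 2

The compounds below may be only part of what the source reports. "The series", "measured", "known", "first", "only" and "open" are said of these compounds alone.

Measured so far:
compound 1, `Nc1ccccc1NC(=O)c1ccc(COc2ccc3ncnc(Nc4cccc(Br)c4)c3c2)cc1`: > 32000 nM
compound 2, `C#Cc1cccc(Nc2ncnc3ccc(S(=O)(=O)n4ccc(/C=C/C(=O)Nc5ccccc5N)c4)cc23)c1`: > 32000 nM

Both compounds were read in an assay on cells for inhibition of histone deacetylase 8 (Homo sapiens), read by fluorescence, with a stated time of 180 min; on this read-out lower numbers stand for stronger inhibition and higher numbers for weaker inhibition. Compound 1 gives only a limit there, > 32000 nM. Compound 2 likewise gives only a limit, > 32000 nM. Among the measured compounds shown here, compound 2 thus stands at the limit at which both of the values shown sit (the limit of > 32000 nM in this assay, at which 2 of the 2 values shown sit); no number for it is known, and no step between measured compounds exists.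

Compound 3, `C#Cc1cccc(Nc2ncnc3ccc(S(=O)(=O)n4ccc(/C=C/C(=O)NO)c4)cc23)c1`, differs from compound 2 in one place: hydroxy in place of 2-aminophenyl on an amide-type nitrogen, so that the (2-aminophenyl)carbamoyl group of compound 2 becomes hydroxycarbamoyl. For the measured compounds named here, no measured step covers this change. The step from compound 2 to compound 3 is expected to be a large gain in inhibition, an at least 160-fold lower number from compound 2 to compound 3 (2.20 log units; beyond the scatter), well beyond the scatter. Compound 3 is estimated at 200 nM, with an expected range from 30 nM to 3000 nM.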

Compound 3, half-maximal inhibitory concentration: 590 nM
The estimate for compound 3 lay 3.0-fold (0.47 log units) below the measured number; measured number inside the range.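

Hydroxy in place of 2-aminophenyl on an amide-type nitrogen gives an at least 54-fold lower number from compound 2 to compound 3 (1.73 log units; beyond the scatter) in this assay and yields the only number in the series that is not a limit. The rest of compound 2 stays unchanged in compound 3, so this single place on the amide decides whether a number can be read at all. The step is a bound and not a size, as compound 2 gives only a limit, and the 2-aminophenyl amides compound 1 and compound 2 share that limit: the limit of > 32000 nM in this assay, at which 2 of the 3 values shown sit.

As far as these compounds go, how far the true step reaches stays open, as does what a methoxy or amino group on the same nitrogen, or a carboxylic acid in place of hydroxycarbamoyl, would give. Also open, from the compounds shown here alone, is whether hydroxycarbamoyl would produce a similar change on the core of compound 1.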